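Replacing pyridin-2-yl with 1-methyl-1H-imidazol-2-yl

The source may hold more compounds than are shown below. What is called first, only, known or untested is meant among the compounds shown, and "the series" means these compounds.

Three measured compounds share one core and differ only in the ring on a double-bonded chain carbon bound to a double-bonded chain carbon. In a functional assay for inhibition, with Homo sapiens as the target (on this read-out higher numbers stand for weaker inhibition and lower numbers for stronger inhibition), compound 1 (`COc1cc(OC)c(C(=O)/C=C/c2c(F)cccc2F)c(OC)c1`), with 2,6-difluorophenyl, gives 1290 nM. Compound 2 (`COc1cc(OC)c(C(=O)/C=C/c2ccncc2)c(OC)c1`), with pyridin-4-yl, gives 592 nM, and compound 3 (`COc1cc(OC)c(C(=O)/C=C/c2ccccn2)c(OC)c1`), with pyridin-2-yl, gives 596 nM.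

Compound 3 cannot be told apart from compound 2, since the data show a 1.0-fold higher number from compound 2 to compound 3 (0.00 log units; within the scatter). Both stand on the stronger-inhibition side of the 2,6-difluorophenyl compound, with modest steps: a 2.2-fold lower number from compound 1 to compound 3 (0.34 log units; beyond the scatter) and a 2.2-fold lower number from compound 1 to compound 2 (0.34 log units; beyond the scatter).

The next compound, compound 4 (`COc1cc(OC)c(C(=O)/C=C/c2nccn2C)c(OC)c1`), has not been measured. It differs from compound 3 in one place: 1-methyl-1H-imidazol-2-yl in place of pyridin-2-yl on a double-bonded chain carbon bound to a double-bonded chain carbon. Among the measured compounds shown here, no measured compound carries a five-membered ring, so the three measured steps offer only indirect guidance. Among them, the exchange of one ring for another produced at most a modest change, and the exchange closest in kind, a 1.0-fold higher number from compound 2 to compound 3 (0.00 log units; within the scatter), produced none beyond the scatter. In this assay, no step beyond the scatter is therefore expected, and the estimated step is a 1.1-fold higher number from compound 3 to compound 4 (0.04 log units; within the scatter). Compound 4 is expected at about 650 nM, with an estimated range from 250 nM to 1700 nM.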

Compound 4, half-maximal inhibitory concentration: 3800 nM
Estimate against measurement, compound 4: 5.8-fold (0.77 log units) below; measured number above the stated range.
By their numbers in this assay, from the lowest: compounds 2 and 3 (each within the scatter of the next); then compound 1; then compound 4.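

In this assay, the change from pyridin-2-yl to 1-methyl-1H-imidazol-2-yl gives the largest steps yet seen at this position on a double-bonded chain carbon (a 6.4-fold higher number from compound 3 to compound 4 (0.80 log units; beyond the scatter) and a 6.4-fold higher number from compound 2 to compound 4 (0.81 log units; beyond the scatter)), so this place does respond to which ring sits there, even though the two pyridine rings could not be told apart. Among the compounds shown here, compound 4 is also the first ring exchange to land on the weaker-inhibition side of the 2,6-difluorophenyl compound (a 2.9-fold higher number from compound 1 to compound 4 (0.47 log units; beyond the scatter)), which makes it the weakest inhibitor of the four. The leaving and entering rings hold the same number of heavy atoms, so that count does not separate them, and nothing measured here accounts for the loss.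

The entering group differs from pyridin-2-yl in ring size, in its hetero atoms and in carrying a methyl group all at once, and the compounds shown cannot pull these apart. A 1H-imidazol-2-yl ring without the methyl, or a 1-methyl-1H-pyrrol-2-yl ring with one nitrogen only, would show which of these features goes with the higher number.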